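The compounds below may be only part of what the source reports. "The series", "measured", "known", "first", "only" and "open" are said of these compounds alone.

Three compounds share one core, differing only in the group carried at one end. Compound 1 `Oc1ccccc1CNc1ccc(N2CCCC2)cc1` is reported in a functional assay on Jurkat cells (Homo sapiens) for activation, with a stated time of 24 h (on this read-out lower numbers stand for an effect already at smaller amounts and higher numbers for an effect only at larger amounts of compound), as "not active" (no number reported). Compound 2 `Oc1ccccc1CNc1ccc(-c2ccccc2)cc1` gives 1820 nM, the lowest of the two numbers available, while compound 3 `Cc1ccc(-c2ccc(NCc3ccccc3O)cc2)cc1` gives 3790 nM. Within the data shown here, the single measured step, a 2.1-fold higher number from compound 2 to compound 3 (0.32 log units; beyond the scatter), is modest. Compound 4 `N#Cc1ccccc1-c1ccc(NCc2ccccc2O)cc1` differs from compound 2 by cyano in place of hydrogen on an aromatic carbon. Among the measured compounds shown here, no measured step involves a cyano group, so the step from compound 2 to compound 3 is the only guide; it shows that adding a small group to this part of the core moves the number only modestly, so a modest rise or no change beyond the scatter is expected. Compound 4 is therefore estimated at 2600 nM, with a range from 900 nM to 7500 nM. The expected step is a 1.4-fold higher number from compound 2 to compound 4 (0.15 log units; within the scatter).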

Compound 4, half-maximal effective concentration: "not active" (no number reported)
Compound 4: no number reported, so the estimate cannot be set against anything.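

Among these compounds, compound 4 has no number, so no step from compound 2 to compound 4 can be read, and no measured evidence bears on this result. The compounds shown leave open how large a change cyano in place of hydrogen brings.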